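This account rests on a few compounds, and the source may have more. Where it says the series, first, only, none or still open, it means among the compounds named here.

Of the compounds shown here, three sharing one core have been tested in a functional assay on CHO cells for agonist activity at Alpha-2B adrenergic receptor (Homo sapiens); on this read-out higher numbers stand for an effect only at larger amounts of compound and lower numbers for an effect already at smaller amounts. Compound 1 `Cc1cccc(C)c1OC(C)C1=NCCN1` gives 1480 nM, compound 2 `CC(Oc1ccccc1Br)C1=NCCN1` gives 316 nM, and compound 3 `C=CCc1cccc(CC=C)c1OC(C)C1=NCCN1` gives 501 nM. Among these three numbers compound 2 holds the lowest; its gap to compound 3 stays within the scatter of repeated measurements, while its gap to compound 1 lies beyond it. The unmeasured compound 4 `COc1ccccc1OC(C)C1=NCCN1` arises from compound 2 by a single change on the aromatic ring: methoxy in place of bromo on an aromatic carbon. Within the data shown here, no pair of measured compounds differs in exactly this place, so no measured step shows what exchanging bromo for methoxy at that site does. Compound 2 carries the only halogen of the set and also the lowest number, and since compound 2 gives 316 nM while compound 1 gives 1480 nM, a moderate rise is expected for compound 4, a step of a 2.5-fold higher number from compound 2 to compound 4 (0.40 log units; beyond the scatter) in this assay. Compound 4 is thus estimated at 800 nM, with a likely range from 250 nM to 2500 nM.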

Compound 4, half-maximal effective concentration: 100000 nM
Compound 4: middle estimate off by 130-fold (2.10 log units), on the low side; the whole stated range lies below it.
By their numbers in this assay, from the lowest: compounds 2 and 3 (each within the scatter of the next); then compound 1; then compound 4.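

In this assay, methoxy in place of bromo on an aromatic carbon, ortho to a group of 8 heavy atoms, brings a 320-fold higher number from compound 2 to compound 4 (2.50 log units; beyond the scatter) and so marks this site as highly sensitive to the exchange. Among these compounds, the change is small by count, with 1 heavy atom leaving, 2 entering and 1 hydrogen-bond acceptor added, yet that is enough for a large step, something the earlier compounds could not show because no measured pair differed at this site. No measurement at hand accounts for the size of this step.

The compounds shown leave open whether chloro, a hydroxyl or an amine at this site would stay close to compound 2 or move as far as compound 4. They also leave open whether ethoxy, with its longer chain, would follow methoxy.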